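The source may hold more compounds than are shown below. What is called first, only, known or untested is meant among the compounds shown, and "the series" means these compounds.

Compound 1 `Cc1cc(-c2ccc(C#N)cc2)cc(C)c1Oc1cc(N)nc(Nc2ccc(C#N)cc2)n1`, compound 2 `Cc1cc(-c2ccc(C#N)c(F)c2)cc(C)c1Oc1cc(N)nc(Nc2ccc(C#N)cc2)n1`, compound 3 `Cc1cc(-c2ccc(C#N)cc2)ccc1Oc1cc(N)nc(Nc2ccc(C#N)cc2)n1` and compound 4 `Cc1cc(-c2ccc(C#N)c(F)c2)ccc1Oc1cc(N)nc(Nc2ccc(C#N)cc2)n1` are four closely related molecules that differ only in small groups on the shared core. The question asked of them is how much of each a human cell line tolerates, which is what a toxicity assay on MT4 cells (Homo sapiens) for cytotoxicity, read by MTT assay (a higher number here means that more compound is tolerated, a lower number that less compound is tolerated), measures. In this assay compound 1 gives 18100 nM. Compound 2 differs from compound 1 by fluoro in place of hydrogen on an aromatic carbon, and in this assay compound 2 gives 5000 nM, which is a 3.6-fold lower number from compound 1 to compound 2 (0.56 log units; beyond the scatter). Compound 3 differs from compound 1 by hydrogen in place of methyl on an aromatic carbon; in this assay compound 3 gives 10400 nM, which is a 1.7-fold lower number from compound 1 to compound 3 (0.24 log units; within the scatter), so the two cores cannot be told apart on this read-out. Compound 4 has not been measured. Among the compounds with values here, it differs from compound 3 by fluoro in place of hydrogen on an aromatic carbon, and this is the same change as the one made from compound 1 to compound 2, at a place described in the same words both times. Within the data shown here, the step from compound 3 to compound 4 in this assay is therefore expected to be about a 3.3-fold lower number from compound 3 to compound 4 (0.51 log units; beyond the scatter), of the same kind and size as the earlier step, because a 3.6-fold lower number from compound 1 to compound 2 (0.56 log units; beyond the scatter) is the only guide available for this change on this core. On that basis compound 4 is expected to give about 3200 nM in this assay. The estimated range for compound 4 runs from 1400 nM to 7500 nM.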

Compound 4, half-maximal cytotoxic concentration: 6600 nM
Compound 4: the middle estimate sits 2.1-fold (0.31 log units) below what was measured; low and high end bracket the measured number.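

Fluoro in place of hydrogen, which turns the 4-cyanophenyl group into the 4-cyano-3-fluorophenyl group, gives a 1.6-fold lower number from compound 3 to compound 4 (0.20 log units; within the scatter) in this assay, and this step cannot be told apart from the earlier one on the other core: the same change on two cores in this assay, a 3.6-fold lower number (0.56 log units; beyond the scatter) from compound 1 to compound 2 and a 1.6-fold lower number (0.20 log units; within the scatter) from compound 3 to compound 4, 2.3-fold (0.36 log units) apart, within the scatter of two such steps

Hydrogen in place of methyl gives a 1.3-fold higher number from compound 2 to compound 4 (0.12 log units; within the scatter), and this step also cannot be told apart from its earlier counterpart: the same change on two cores in this assay, a 1.7-fold lower number (0.24 log units; within the scatter) from compound 1 to compound 3 and a 1.3-fold higher number (0.12 log units; within the scatter) from compound 2 to compound 4, 2.3-fold (0.36 log units) apart, within the scatter of two such steps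

So both changes can be carried from one core to the other without a difference that this read-out can detect, but this does not show that their sizes are the same on both cores, since each comparison rests on only two steps, and a real but modest difference could be hidden in the scatter.

The four compounds cannot say whether the same holds on any other core, or for a group other than fluoro in the same place, such as chloro, methoxy or an amine. They also leave open what a fluoro elsewhere on this ring would do to the number of compound tolerated.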